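The source may hold more compounds than are shown below. What is called first, only, known or untested is meant among the compounds shown, and "the series" means these compounds.

Three compounds share one core and differ only in the group on the carbonyl carbon. Compound 1 `O=C(NCc1cccc(Cn2cnc3ccccc32)c1)c1cc(Br)c[nH]1` gives 16 nM in an assay for inhibition of Indoleamine 2,3-dioxygenase 1 (Homo sapiens), read by HPLC, with a stated time of 48 h; a lower number here means a stronger inhibitor, a higher number a weaker inhibitor. Compound 2 `Cc1ccc(C(=O)NCc2cccc(Cn3cnc4ccccc43)c2)cc1` gives 327 nM, and compound 3 `O=C(NCc1cccc(Cn2cnc3ccccc32)c1)c1ccc(F)cc1` gives 961 nM, the highest number of the three: the step of a 60-fold higher number from compound 1 to compound 3 (1.78 log units; beyond the scatter) is large, and a 2.9-fold higher number from compound 2 to compound 3 (0.47 log units; beyond the scatter) is modest. Compound 4 `N#Cc1ccc(C(=O)NCc2cccc(Cn3cnc4ccccc43)c2)cc1` differs from compound 3 by cyano in place of fluoro on an aromatic carbon. Within the data shown here, the only measured step on that aromatic carbon is a 2.9-fold higher number from compound 2 to compound 3 (0.47 log units; beyond the scatter), modest in size, whereas the steps away from the 4-bromo-1H-pyrrol-2-yl group, a 20-fold higher number from compound 1 to compound 2 (1.31 log units; beyond the scatter) and a 60-fold higher number from compound 1 to compound 3 (1.78 log units; beyond the scatter), are larger. Among the measured compounds shown here, no measured compound carries cyano there, so the expected step of a 1.6-fold lower number from compound 3 to compound 4 (0.20 log units; within the scatter) is small in either direction. Compound 4 is therefore estimated at 600 nM, with a range from 200 nM to 2000 nM.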

Compound 4, half-maximal inhibitory concentration: 90 nM
Compound 4: middle estimate off by 6.7-fold (0.82 log units), on the high side, outside the stated range (below it).
By their numbers in this assay, from the lowest: compound 1; then compound 4; then compound 2; then compound 3.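

The step of an 11-fold lower number from compound 3 to compound 4 (1.03 log units; beyond the scatter) in this assay and the step of a 3.6-fold lower number from compound 2 to compound 4 (0.56 log units; beyond the scatter) show that this aromatic carbon, para to a large group, can shift the number much further than methyl and fluoro alone had shown. The step of a 5.6-fold higher number from compound 1 to compound 4 (0.75 log units; beyond the scatter) is smaller than the steps from compound 1 to the methyl and fluoro compounds, yet the 4-bromo-1H-pyrrol-2-yl group stays ahead of the 4-cyanophenyl group. Nothing measured here accounts for the gain with cyano. Going by these compounds, whether a primary amide, a methoxy group or a carboxylic acid on this carbon would match cyano stays open.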